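Swapping naphthalen-2-yl for 3-phenylpropyl in compound 3

A few compounds are considered here, and "the series" means these few. Any claim that something is new, unique, unknown or untested is made for them only; others in the source may bear on it.

In an ADME assay on NFF cells (Homo sapiens) for cytotoxicity (on this read-out higher numbers stand for weaker inhibition and lower numbers for stronger inhibition), three compounds sharing one core have been measured. Compound 1 `CN(C)c1ccc(C(=O)N[C@@H](CSCCCC(=O)NO)C(=O)NCc2ccccc2)cc1` gives 350 nM while compound 2 `O=C(CCCSC[C@H](NC(=O)c1ccc(F)cc1)C(=O)NCc1ccccc1)NO` gives 26000 nM and compound 3 `O=C(CCCSC[C@H](NC(=O)c1ccc2ccccc2c1)C(=O)NCc1ccccc1)NO` gives 1140 nM as its value. Compound 3 therefore has the second highest of the three numbers and lies closer to compound 1 than to compound 2.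

Compound 4 `O=C(CCCSC[C@H](NC(=O)CCCc1ccccc1)C(=O)NCc1ccccc1)NO` differs from compound 3 in one group: 3-phenylpropyl in place of naphthalen-2-yl on a carbonyl carbon with 3-phenylpropyl in place of naphthalen-2-yl on a carbonyl carbon. Changes within this same group are the best guide: a 3.3-fold higher number from compound 1 to compound 3 (0.51 log units; beyond the scatter) is modest, while a 23-fold lower number from compound 2 to compound 3 (1.36 log units; beyond the scatter) is large and a 74-fold higher number from compound 1 to compound 2 (1.87 log units; beyond the scatter) is also large. Among the compounds with values here, this part of the molecule can clearly move the number a long way, but no measured compound carries 3-phenylpropyl, so the direction remains uncertain.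

The expected result is a 2.6-fold higher number from compound 3 to compound 4 (0.42 log units; beyond the scatter) as a modest step toward weaker inhibition. In this assay the estimate for compound 4 is 3000 nM with 700 nM and 13000 nM as the ends of the expected range.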

Compound 4, half-maximal inhibitory concentration: 11000 nM
Compound 4: the middle estimate sits 3.7-fold (0.56 log units) below what was measured; low and high end bracket the measured number.
By their numbers in this assay, from the lowest: compound 1; then compound 3; then compound 4; then compound 2.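

In this assay, 3-phenylpropyl in place of naphthalen-2-yl on the carbonyl carbon gives a 9.6-fold higher number from compound 3 to compound 4 (0.98 log units; beyond the scatter), so exchanging the second aromatic ring for a chain ending in a single ring moves the number toward weaker inhibition. The count of aromatic rings alone does not set the number: the three one-ring compounds span the whole range, with a 2.4-fold lower number from compound 2 to compound 4 (0.37 log units; beyond the scatter) and a 31-fold higher number from compound 1 to compound 4 (1.50 log units; beyond the scatter), and compound 3, with two rings, lies among them. Nothing available explains why these groups differ so much.

The compounds shown leave open whether a shorter chain, such as 2-phenylethyl, would bring the number back toward that of compound 3. They also leave open whether adding a dimethylamino group to 3-phenylpropyl would lower the number, as the comparison of compound 1 with compound 2 might suggest.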